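The source may report more compounds than this note shows. Statements on the series, on what has been measured and on what is new or still open speak of the compounds shown alone.

Measured so far in a functional assay on MIA PaCa-2 cells (Homo sapiens) for inhibition, read by MTT assay, with a stated time of 3 days; on this read-out lower numbers stand for stronger inhibition and higher numbers for weaker inhibition:
compound 1, `CCN(CC)S(=O)(=O)c1ccc(S(=O)(=O)N2CCC[C@@H](C(=O)N[C@H]3CC[C@H](OC)CC3)C2)cc1`: compound 1 gives 2290 nM
compound 2, `CCN(CC)S(=O)(=O)c1ccc(S(=O)(=O)N2CCC[C@@H](C(=O)N3CCC(O)CC3)C2)cc1`: compound 2 gives 230 nM

Compound 2 stands at the lowest of the two numbers; its nearest neighbour is compound 1, separated by the step of a 10-fold lower number from compound 1 to compound 2 (1.00 log units; beyond the scatter). That step rewrites the whole amide substituent, 4-hydroxypiperidin-1-yl in place of (4-methoxycyclohexyl)amino on a carbonyl carbon, so it combines several changes and does not isolate any one of them.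

Compound 3, `CCN(CC)S(=O)(=O)c1ccc(S(=O)(=O)N2CCC[C@@H](C(=O)N3CCC(OC)CC3)C2)cc1`, is to be measured in this assay. It differs from compound 2 by methyl in place of hydrogen on an oxygen on a saturated carbon. Within the data shown here, no measured step changes a hydroxy to a methoxy on an otherwise unchanged scaffold, so nothing recorded bears directly on this step; the only step known, from compound 1 to compound 2, alters a different part of the substituent and gives no guidance in either direction for compound 3. The expectation is therefore a step of a 1.4-fold higher number from compound 2 to compound 3 (0.14 log units; within the scatter), not beyond the scatter, with wide uncertainty. Compound 3 is estimated at 320 nM, within 100 nM to 1100 nM.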

Compound 3, half-maximal inhibitory concentration: 50 nM
For compound 3 the middle estimate is 6.4-fold (0.81 log units) above the measured one; the measured number lies below the stated range.
By their numbers in this assay, from the lowest: compound 3; then compound 2; then compound 1.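

Working notes on the series: in this assay, the oxygen on the saturated carbon of the 4-hydroxypiperidin-1-yl group accepts a methyl, and hydroxy to methoxy gives a 4.6-fold lower number from compound 2 to compound 3 (0.66 log units; beyond the scatter) on an otherwise unchanged scaffold, so the hydrogen on this oxygen is not needed for inhibition in this pair. With methoxy present on both sides, 4-methoxypiperidin-1-yl in place of (4-methoxycyclohexyl)amino gives a 46-fold lower number from compound 1 to compound 3 (1.66 log units; beyond the scatter) and makes compound 3 the most potent of the three, so the gain from changing the amide substituent does not depend on a free hydroxy. No available measurement accounts for either step.

Open, going by these compounds, is whether a longer chain on this oxygen, such as ethoxy or propoxy, extends the gain or loses it, and whether an amine or a fluorine on the same saturated carbon can stand in for the methoxy. Also open, on these data alone, is how the shared core, including its diethylsulfamoyl group, behaves with 4-methoxypiperidin-1-yl in place.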